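A few compounds are considered here, and "the series" means these few. Any claim that something is new, unique, unknown or untested is made for them only; others in the source may bear on it.

The measured compounds:
Compound 1, `O=C(O)CCc1ccc(C#CC2CC2)cc1`, gives 5010 nM in a functional assay on 1321-N1 cells for agonist activity at Free fatty acid receptor 1 (Homo sapiens), read by calcium flux, with a stated time of 0.4 s; a higher number here means that more compound is needed for the effect, a lower number that less compound is needed.
Compound 2, `C#Cc1ccc(CCC(=O)O)cc1`, reaches only the limit of this assay, > 100000 nM.
Compound 3, `O=C(O)CCc1ccc(C#CC2CCCCC2)cc1`, gives 513 nM in this assay.

Compound 3 holds the lowest of the two numbers actually reported; its nearest neighbour is compound 1, and the step from that compound runs as a 9.8-fold lower number from compound 1 to compound 3 (0.99 log units; beyond the scatter). Compound 4, `C=C(C)C#Cc1ccc(CCC(=O)O)cc1`, differs from compound 3 in a single place: 1-methylethenyl in place of cyclohexyl on a triple-bonded carbon. The measured steps at this same triple-bonded carbon all point one way. Replacing cyclopropyl by cyclohexyl gave a 9.8-fold lower number from compound 1 to compound 3 (0.99 log units; beyond the scatter), stripping the cyclopropyl down to hydrogen gave an at least 19-fold higher number from compound 1 to compound 2 (1.30 log units; beyond the scatter), and across the whole span an at least 190-fold lower number from compound 2 to compound 3 (2.28 log units; beyond the scatter). One value in this series is only a limit, (the limit of > 100000 nM in this assay, at which 1 of the 3 values shown sits), so the full extent of the step to compound 2 is not known. Compound 4 moves back toward the smaller end, trading cyclohexyl for a group of fewer heavy atoms, and a higher number in this assay is therefore expected, likely of modest size rather than the large step seen on removing the group entirely. Compound 4 is estimated at 6000 nM, with a range of 1500 nM to 30000 nM, which amounts to an expected 12-fold higher number from compound 3 to compound 4 (1.07 log units; beyond the scatter).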

Compound 4, half-maximal effective concentration: 417 nM
Beside the measured number, compound 4's estimate is 14-fold (1.16 log units) above it; measured number outside the range, below it.
By their numbers in this assay, from the lowest: compounds 4 and 3 (each within the scatter of the next); then compound 1. At a limit, above all of these: compound 2.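

At this triple-bonded carbon, the cyclohexyl ring is not required for a low number in this assay: a 1.2-fold lower number from compound 3 to compound 4 (0.09 log units; within the scatter). 1-Methylethenyl, with 3 heavy atoms and no ring, thus does what cyclohexyl, with 6 heavy atoms, does here, and the comparison with the other small group shows that the identity of the group matters, not only the presence of one: a 12-fold lower number from compound 1 to compound 4 (1.08 log units; beyond the scatter). Against hydrogen the step is an at least 230-fold lower number from compound 2 to compound 4 (2.37 log units; beyond the scatter), and its full size remains unknown, since compound 2 gives only a limit: the limit of > 100000 nM in this assay, at which 1 of the 4 values shown sits.

As far as these compounds go, whether an isopropyl group, with the same carbon count as 1-methylethenyl but no double bond, would give a number like that of compound 4 remains open, so what the double bond contributes at this place cannot be told. Equally open, from the compounds shown here alone, is how a longer chain, a phenyl ring or a group carrying an amine or a hydroxyl would read at this triple-bonded carbon in this assay.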